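From 1,3-Thiazol-5-yl to Thiophen-3-yl on the Carbonyl Carbon

The source may hold more compounds than are shown below. What is called first, only, known or untested is meant among the compounds shown, and "the series" means these compounds.

Three amides on a shared core have been measured so far in a functional assay on KM12 cells (Homo sapiens) for inhibition, read by colorimetric assay and sulforhodamine B assay, with a stated time of 48 h (on this read-out lower numbers stand for stronger inhibition of growth and higher numbers for weaker inhibition of growth), with their rings on the carbonyl carbon varied. Compound 1 (`CCCCCCCCCCCC[C@@H](O)[C@H]1CC[C@H]([C@H](O)CCCCCCCCCCNC(=O)c2cccs2)O1`) carries thiophen-2-yl and gives 3090 nM on this read-out. Compound 2 (`CCCCCCCCCCCC[C@@H](O)[C@H]1CC[C@H]([C@H](O)CCCCCCCCCCNC(=O)c2ccco2)O1`) carries furan-2-yl and gives 100000 nM on the same read-out. Compound 3 (`CCCCCCCCCCCC[C@@H](O)[C@H]1CC[C@H]([C@H](O)CCCCCCCCCCNC(=O)c2cncs2)O1`) carries 1,3-thiazol-5-yl and gives 100000 nM as well, level with compound 2 and, together with it, the highest of the three numbers.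

Compound 4 (`CCCCCCCCCCCC[C@@H](O)[C@H]1CC[C@H]([C@H](O)CCCCCCCCCCNC(=O)c2ccsc2)O1`) is still unmeasured. It has thiophen-3-yl in place of 1,3-thiazol-5-yl on a carbonyl carbon. The measured steps that bear on this are a 32-fold higher number from compound 1 to compound 2 (1.51 log units; beyond the scatter) and a 32-fold higher number from compound 1 to compound 3 (1.51 log units; beyond the scatter) when thiophen-2-yl is replaced, both large, and no change at the digits printed from compound 2 to compound 3 (within the scatter) between the two replacements. Compound 4 keeps a thiophene, the ring of compound 1 (3090 nM), although no thiophen-3-yl amide has a measured number yet. In this assay the estimated step is a 17-fold lower number from compound 3 to compound 4 (1.22 log units; beyond the scatter) (expected to be large, towards a lower number, but uncertain). Compound 4 is estimated at 6000 nM (expected range 1500 nM to 60000 nM).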

Compound 4, concentration for 50% growth inhibition: 3020 nM
For compound 4 the middle estimate is 2.0-fold (0.30 log units) above the measured one; the measured number falls inside the stated range.
By their numbers in this assay, from the lowest: compounds 4 and 1 (each within the scatter of the next); then compounds 2 and 3 (each within the scatter of the next).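

Replacing 1,3-thiazol-5-yl with thiophen-3-yl on the carbonyl carbon gives a 33-fold lower number from compound 3 to compound 4 (1.52 log units; beyond the scatter) in this assay, and replacing furan-2-yl with thiophen-3-yl gives a 33-fold lower number from compound 2 to compound 4 (1.52 log units; beyond the scatter). Exchanging one thiophene for the other, thiophen-3-yl in place of thiophen-2-yl, gives a 1.0-fold lower number from compound 1 to compound 4 (0.01 log units; within the scatter), so the low numbers at this position are no longer confined to a single ring. Across these four amides, the two thiophenes stand together and apart from the furan-2-yl and 1,3-thiazol-5-yl amides, and whether the ring is thiophen-2-yl or thiophen-3-yl makes no difference beyond the scatter in this read-out, with no compound shown going against this pattern.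

No supporting data are available to account for this split among the rings. The compounds shown leave open whether a phenyl ring, or a thiophen-3-yl ring carrying a chlorine or a methyl group, would keep the same level on the carbonyl carbon, and whether the thiophene result would hold with a shorter chain linking the amide to the shared core.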